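From oxetan-3-yl to (dimethylamino)methyl on compound 2

A few compounds are considered here, and "the series" means these few. Any claim that something is new, unique, unknown or untested is made for them only; others in the source may bear on it.

Measured so far in a functional assay on U2OS cells for antagonist activity at C-X-C chemokine receptor type 3 (Homo sapiens), read by beta-arrestin recruitment; on this read-out lower numbers stand for stronger inhibition and higher numbers for weaker inhibition:
compound 1 `C[C@@H]1CN(c2scnc2-c2nc3ccccc3[nH]2)CCN1C(=O)Cn1cnc2cccnc21` gives 830 nM
compound 2 `C[C@@H]1CN(c2sc(C3COC3)nc2-c2nc3ccccc3[nH]2)CCN1C(=O)Cn1cnc2cccnc21` gives 6220 nM

Compound 2 stands highest of the two numbers; its nearest neighbour is compound 1, and the two are separated by a 7.5-fold higher number from compound 1 to compound 2 (0.87 log units; beyond the scatter). Compound 3 `C[C@@H]1CN(c2sc(CN(C)C)nc2-c2nc3ccccc3[nH]2)CCN1C(=O)Cn1cnc2cccnc21` differs from compound 2 by (dimethylamino)methyl in place of oxetan-3-yl on an aromatic carbon. Within the data shown here, only one measured step bears on this position: from compound 1 to compound 2, placing oxetan-3-yl where hydrogen stood gave a 7.5-fold higher number from compound 1 to compound 2 (0.87 log units; beyond the scatter), a modest step beyond the scatter. Among the measured compounds shown here, no measured compound carries (dimethylamino)methyl, so the effect of that group in this assay is not known from these data. Compound 3 is therefore expected to land somewhere between the two measured values, a step of a 2.1-fold lower number from compound 2 to compound 3 (0.32 log units; beyond the scatter), with a wide range. The estimate for compound 3 in this assay is 3000 nM, between 700 nM and 12000 nM.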

Compound 3, half-maximal inhibitory concentration: 2360 nM
Beside the measured number, compound 3's estimate is 1.3-fold (0.10 log units) above it; the range from low to high includes it.
By their numbers in this assay, from the lowest: compound 1; then compound 3; then compound 2.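

In this assay, a second group on this aromatic carbon also raises the number over hydrogen, with a 2.8-fold higher number from compound 1 to compound 3 (0.45 log units; beyond the scatter), so among the three compounds the unsubstituted core of compound 1 remains the lowest. The position also distinguishes between two groups of equal heavy-atom count: the open (dimethylamino)methyl, with its nitrogen, and the four-membered oxetan-3-yl ring, with its oxygen, are separated by a 2.6-fold lower number from compound 2 to compound 3 (0.42 log units; beyond the scatter). No independent data accompany these results to explain that difference.

The compounds shown leave open whether the ring or the hetero atom accounts for the separation, which azetidin-3-yl, a four-membered ring carrying nitrogen, could help to resolve. They also leave open whether a group as small as methyl would stay close to compound 1.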